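Bulkier Silicon Group on the Primary Alcohol Oxygen

A few compounds are considered here, and "the series" means these few. Any claim that something is new, unique, unknown or untested is made for them only; others in the source may bear on it.

In an ADME assay on HEL cells (Homo sapiens) for cytotoxicity, with a stated time of 3 days (on this read-out lower numbers stand for higher toxicity in this test and higher numbers for lower toxicity in this test), compound 1 `Cc1cn([C@@H]2O[C@H](CO[Si](C)(C)C(C)(C)C)[C@@]3(OS(=O)(=O)C=C3NC(=O)NC(=O)c3ccccc3)[C@H]2O[Si](C)(C)C(C)(C)C)c(=O)n(C)c1=O` gives > 200000 nM, which is a limit of the test. Compound 2 `Cc1cn([C@@H]2O[C@H](CO)[C@@]3(OS(=O)(=O)C=C3NC(=O)NC(=O)c3ccccc3)[C@H]2O[Si](C)(C)C(C)(C)C)c(=O)n(C)c1=O` gives 16000 nM. Compound 3 `Cc1cn([C@@H]2O[C@H](CO[Si](C)(C)C(C)(C)C(C)C)[C@@]3(OS(=O)(=O)C=C3NC(=O)NC(=O)c3ccccc3)[C@H]2O[Si](C)(C)C(C)(C)C)c(=O)n(C)c1=O` gives > 50000 nM, again a limit.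

Compound 3 thus stands only at a limit in this assay, as one other value shown also does (the limit of > 50000 nM in this assay, at which 1 of the 3 values shown sits). Compound 4 `Cc1cn([C@@H]2O[C@H](CO[Si](C(C)C)(C(C)C)C(C)C)[C@@]3(OS(=O)(=O)C=C3NC(=O)NC(=O)c3ccccc3)[C@H]2O[Si](C)(C)C(C)(C)C)c(=O)n(C)c1=O` differs from it by a group of 10 heavy atoms (9 carbon, 1 silicon; no ring) in place of a group of 9 heavy atoms (8 carbon, 1 silicon; no ring), on an oxygen on a saturated carbon. Going by the values given here, two measured steps touch this same oxygen: an at least 12-fold lower number from compound 1 to compound 2 (1.09 log units; beyond the scatter), and an at least 3.1-fold higher number from compound 2 to compound 3 (0.49 log units; beyond the scatter). Among these three compounds, a group holding silicon on that oxygen goes with a higher number, while the step from compound 1 to compound 3 stays unreadable. Since compound 4 keeps such a group there, only a small step is expected, a step that the limit leaves unreadable from compound 3 to compound 4. Compound 4 is expected near 100000 nM, between 30000 nM and 300000 nM, and may again come out only as a limit.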

Compound 4, half-maximal cytotoxic concentration: > 100000 nM
Compound 4 was reported as a limit (the forecaster's own chance of this, stated with the estimate: 70%); the middle value sits exactly at the limit.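

Like the two smaller silicon groups, the group of 10 heavy atoms (9 carbon, 1 silicon; no ring) on this oxygen goes with a higher number than the free alcohol, with an at least 6.2-fold higher number from compound 2 to compound 4 (0.79 log units; beyond the scatter) in this assay. Compound 4 gives > 100000 nM, which is a limit. The steps among compound 1, compound 3 and compound 4 cannot be read, so no order among these silicon groups can be given.

On these data alone, the true values of these three compounds remain open. So does whether a group without silicon on this oxygen, such as methyl or acetyl, would also go with a higher number than compound 2.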